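Lengthening a Side Chain: From Compound 1 to Compound 4

A few compounds are considered here, and "the series" means these few. Any claim that something is new, unique, unknown or untested is made for them only; others in the source may bear on it.

Compound 1, `CCCOCNc1n[n+]([O-])c2cc(OC)ccc2[n+]1[O-]`: 2810 nM
Compound 2, `[O-][n+]1nc(NCOC2CCCCC2)[n+]([O-])c2ccccc21`: 5180 nM
Compound 3, `[O-][n+]1nc(NCOCc2ccc(Cl)cc2)[n+]([O-])c2ccccc21`: 1470 nM

All three compounds were tested in a functional assay on A549 cells (Homo sapiens) for cytotoxicity, read by MTT assay, with a stated time of 72 h; a higher number here means a weaker inhibitor, a lower number a stronger inhibitor. They share a core and differ in the group carried on the chain attached through the nitrogen. On these three numbers compound 1 takes the middle place, yet its gap to compound 2 and its gap to compound 3 both fall within the usual scatter of repeated measurements, so the three compounds cannot be told apart on this evidence.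

Compound 4, `CCCCCOCNc1n[n+]([O-])c2cc(OC)ccc2[n+]1[O-]`, is not yet measured. It differs from compound 1 in one place: ethyl in place of hydrogen on a saturated chain carbon, three bonds along the chain from an oxygen on a saturated carbon. The chain grows from propyl to pentyl, while the core and the rest of the molecule stay unchanged.

No measured pair among these compounds shows the effect of extending a chain in this way, so nothing here points to a change beyond the scatter. The step from compound 1 to compound 4 in this assay is expected to be small, a 1.1-fold higher number from compound 1 to compound 4 (0.03 log units; within the scatter), in no firm direction. Compound 4 is therefore estimated at 3000 nM, with a likely range from 1200 nM to 7500 nM.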

Compound 4, half-maximal inhibitory concentration: 5040 nM
Compound 4: the middle estimate sits 1.7-fold (0.23 log units) below what was measured, and the stated range covers the measured number.
By their numbers in this assay, from the lowest: compounds 3, 1, 4 and 2 (each within the scatter of the next, the first and the last beyond it).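

Going by these compounds alone, this is the first pair in the set that differs in only one place, so it isolates a single change: ethyl in place of hydrogen on a saturated chain carbon, three bonds along the chain from an oxygen on a saturated carbon, which turns propyl into pentyl. In this assay the step reads a 1.8-fold higher number from compound 1 to compound 4 (0.25 log units; within the scatter) and so shows that, on the core of compound 1, adding these two carbons at this place gives no difference that can be separated from ordinary repeat variation. No supporting measurement is available to explain this outcome or connect it to any property of the chain.

One step at one chain length cannot show whether a longer chain, such as heptyl, would stay within the scatter or move beyond it. Also open is whether a chain of similar length ending in an amine or a carboxylic acid would be tolerated equally well at this place, since the compounds shown carry only carbon-based end groups there.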